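The source may report more compounds than this note shows. Statements on the series, on what has been measured and on what is new or still open speak of the compounds shown alone.

Among the compounds with values here, compound 2 `C/C(=N\Cc1ccccn1)c1c(O)c2ccccc2oc1=O` is the only compound here with a definite number in an assay on isolated protein for inhibition of myosin-2 (Bos taurus), read by spectrophotometry, with a stated time of 24 min; on this read-out lower numbers stand for stronger inhibition and higher numbers for weaker inhibition: compound 2 gives 22000 nM. Its neighbour compound 1 `C/C(=N\Cc1ccccc1C)c1c(O)c2ccccc2oc1=O` is known in this assay only as a limit, >= 100000 nM, and the limit of >= 100000 nM in this assay, at which 1 of the 2 values shown sits, marks that limit as the point where one of the two shown values rests. Within the data shown here, the single measured step runs an at least 4.5-fold lower number from compound 1 to compound 2 (0.65 log units; beyond the scatter), so within this pair the pyridin-2-yl compound is the one with the definite, lower number.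

Compound 3 `CCCCCC/N=C(\C)c1c(O)c2ccccc2oc1=O` is not yet measured. Relative to compound 2 it carries pentyl in place of pyridin-2-yl on a saturated chain carbon bound to a double-bonded nitrogen. Among the measured compounds shown here, the only step that bears on this position is the one from compound 1 to compound 2, where an aromatic hydrocarbon ring gave a limit and a pyridin-2-yl gave a number; a pentyl chain resembles neither, and no measured step covers it.

Compound 3 is therefore expected to sit near or somewhat weaker than compound 2, a step of a 2.3-fold higher number from compound 2 to compound 3 (0.36 log units; beyond the scatter). The estimate for compound 3 in this assay is 50000 nM, with a range from 15000 nM to 150000 nM.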

Compound 3, half-maximal inhibitory concentration: 2900 nM
Compound 3: middle estimate off by 17-fold (1.24 log units), on the high side; the whole stated range lies above it.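

Within the data shown here, at this position, on a saturated chain carbon bound to a double-bonded nitrogen, a ring turns out not to be needed for a definite number: the open pentyl chain gives a 7.6-fold lower number from compound 2 to compound 3 (0.88 log units; beyond the scatter) in this assay and is the first group here to go past pyridin-2-yl. Set against 2-methylphenyl, the same chain gives an at least 34-fold lower number from compound 1 to compound 3 (1.53 log units; beyond the scatter) in this assay and so puts the three groups in the order pentyl, pyridin-2-yl, 2-methylphenyl, which the earlier step between the two ring groups could not reveal. Compound 1 stands at a limit and not at a number, so this last step gives only a bound: the limit of >= 100000 nM in this assay, at which 1 of the 3 values shown sits.

Whether the number keeps falling as the chain changes length stays open, as only one chain is shown, and a shorter butyl chain, a longer octyl chain or a branched isopentyl chain could each answer that. Also open, as far as these compounds go, is whether a cyclohexyl ring, which has no aromatic ring, would behave like pentyl, and whether a chain ending in an amine or a carboxylic acid would keep the number of compound 3.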